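A few compounds are considered here, and "the series" means these few. Any claim that something is new, unique, unknown or untested is made for them only; others in the source may bear on it.

Compounds measured in an assay on isolated protein for inhibition of dual specificity protein phosphatase 3 (Homo sapiens); a higher number here means a weaker inhibitor, a lower number a stronger inhibitor:

Compound 1, `CCCc1sc(NS(=O)(=O)/C=C/c2ccccc2Cl)nc1-c1ccc(-c2ccccc2)cc1`, gives 82000 nM.
Compound 2, `Cc1sc(NS(=O)(=O)/C=C/c2ccccc2Cl)nc1-c1ccc(Cl)cc1`, gives > 100000 nM.

Two compounds carry a number or a limit here. Compound 1 is a weak inhibitor in this assay, giving 82000 nM. Compound 2 is reported only as a limit of this assay, > 100000 nM, so its place on the scale is not a number but the edge at which the assay stops (the limit of > 100000 nM in this assay, at which 1 of the 2 values shown sits). For the measured compounds named here, of the two values shown, then, one is a number and one is a limit, and no step between them can be sized.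

Compound 3, `CCCc1sc(NS(=O)(=O)/C=C/c2ccccc2Cl)nc1-c1ccc(Cl)cc1`, is not yet measured. It differs from compound 2 by ethyl in place of hydrogen on a saturated chain carbon bound to an aromatic carbon; the same change, read one bond further out, is methyl to propyl. Compound 1 carries this propyl chain too, but it differs from compound 3 elsewhere, so its value tells only where one propyl-bearing compound sits. The step from compound 2 to compound 3 is expected to be small, if any, at an at least 1.1-fold lower number from compound 2 to compound 3 (0.04 log units; that floor lies within the scatter). Compound 3 is expected to come in at 90000 nM, within 40000 nM to 200000 nM, with a fair chance that this assay again reports only a limit.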

Compound 3, half-maximal inhibitory concentration: 32000 nM
For compound 3 the middle estimate is 2.8-fold (0.45 log units) above the measured one; the measured number lies below the stated range.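

In this assay, ethyl in place of hydrogen on a saturated chain carbon bound to an aromatic carbon, read one bond further out as methyl to propyl, gives an at least 3.1-fold lower number from compound 2 to compound 3 (0.49 log units; beyond the scatter), the first sign that this chain position affects the read-out. Compound 2 is reported only as a limit of the assay, so this step has a floor and no exact size: the limit of > 100000 nM in this assay, at which 1 of the 3 values shown sits. With the propyl chain held fixed, chloro in place of phenyl on an aromatic carbon gives a 2.6-fold lower number from compound 1 to compound 3 (0.41 log units; beyond the scatter), so the second position also moves the number, and the smaller chloro-bearing compound 3 gives the lower one of the two.

The compounds shown leave open whether the effect of the chain continues with a longer chain such as butyl, or changes with a branched isopropyl group or a chain ending in an amine or a carboxylic acid. They also leave open whether fluoro or methoxy in place of chloro on that aromatic carbon would take compound 3, now at 32000 nM, any further along the scale.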